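A few compounds are considered here, and "the series" means these few. Any claim that something is new, unique, unknown or untested is made for them only; others in the source may bear on it.

Working notes on the series. The read-out throughout is an assay on isolated protein for inhibition of Rho-associated protein kinase 2 (Homo sapiens), read by scintillation counting, radiometric assay and 33P incorporation, with a stated time of 40 min, in the presence of a further agent that is not named here; on this read-out higher numbers stand for weaker inhibition and lower numbers for stronger inhibition. Compound 1, `COC(=O)c1ccc(C(=O)Nc2cccc(NC(=O)COc3ccc4c(=O)ccoc4c3)c2)cc1`, gives 29 nM in this assay. Compound 2, `Nc1ccc(C(=O)Nc2cccc(NC(=O)COc3ccc4c(=O)ccoc4c3)c2)cc1`, gives 83 nM in this assay. Within the data shown here, the single measured step, a 2.9-fold higher number from compound 1 to compound 2 (0.46 log units; beyond the scatter), is modest and lies beyond the scatter. Among the measured compounds shown here, of the two numbers so far, compound 2 stands highest, with compound 1 as its nearest neighbour at the lower number.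

Compound 3, `Nc1cccc(C(=O)Nc2cccc(NC(=O)COc3ccc4c(=O)ccoc4c3)c2)c1`, has not yet been measured. It differs from compound 2 by 3-aminophenyl in place of 4-aminophenyl on a carbonyl carbon. For the measured compounds named here, no measured step bears directly on this change: the only step available, a 2.9-fold higher number from compound 1 to compound 2 (0.46 log units; beyond the scatter), exchanges one group for a different one at the same place, whereas the move from compound 2 to compound 3 keeps the same atoms and only rejoins them. With nothing measured on a rearrangement of this kind, no step beyond the scatter is expected in this assay in either direction, and the range is kept wide to reflect that. Compound 3 is therefore estimated at 100 nM, with a range from 35 nM to 300 nM. The expected step is a 1.2-fold higher number from compound 2 to compound 3 (0.08 log units; within the scatter).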

Compound 3, half-maximal inhibitory concentration: 58 nM
The estimate for compound 3 lay 1.7-fold (0.24 log units) above the measured number; low and high end bracket the measured number.
By their numbers in this assay, from the lowest: compounds 1, 3 and 2 (each within the scatter of the next, the first and the last beyond it).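

In this assay, exchanging 4-aminophenyl for 3-aminophenyl on the carbonyl carbon gives a 1.4-fold lower number from compound 2 to compound 3 (0.16 log units; within the scatter), so this rejoining of the same atoms leaves the two aminophenyl compounds indistinguishable here. The comparison with the 4-(methoxycarbonyl)phenyl group gives a 2.0-fold higher number from compound 1 to compound 3 (0.30 log units; within the scatter), whereas the earlier 2.9-fold higher number from compound 1 to compound 2 (0.46 log units; beyond the scatter) lay beyond the scatter, so the separation from compound 1 holds for 4-aminophenyl and not for 3-aminophenyl. Nothing at hand bears on the reason for either result.

The compounds shown leave open whether the same exchange of 4-substituted for 3-substituted phenyl would also stay within the scatter with a group other than amino, such as a carboxylic acid or a methylamino group. Among these compounds, they also leave open whether the aminophenyl ring is needed at all on this carbonyl carbon, since a plain methyl group or a longer alkyl chain in its place could move the number in either direction, and the three values so far say nothing about that.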